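Compound 3 to compound 4: fluoro for trifluoromethyl

This account rests on a few compounds, and the source may have more. Where it says the series, first, only, none or still open, it means among the compounds named here.

In a functional assay on MDA-MB-468 cells (Homo sapiens) for antiproliferative activity, read by sulforhodamine B assay, with a stated time of 72 h (a lower number here means a stronger inhibitor, a higher number a weaker inhibitor), compound 3 `COc1ccc2nc(Cl)c(/C=C/c3ccc(C(F)(F)F)cc3)cc2c1` stands only at a limit, > 50000 nM.

Its Z counterpart, compound 2 `COc1ccc2nc(Cl)c(/C=C\c3ccc(C(F)(F)F)cc3)cc2c1`, gives 22700 nM. Among the compounds with values here, the one measured step, an at least 2.2-fold higher number from compound 2 to compound 3 (0.34 log units; beyond the scatter), rests on the fact that compounds 2 and 3 differ only in the configuration as drawn and does not touch the group now exchanged.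

Compound 4 `COc1ccc2nc(Cl)c(/C=C/c3ccc(F)cc3)cc2c1` keeps the E double bond of compound 3 and carries fluoro in place of trifluoromethyl on an aromatic carbon, fluoro in place of trifluoromethyl on an aromatic carbon.

Compound 1 `Fc1ccc(/C=C/c2cc3ccccc3nc2Cl)cc1`, also a fluoro compound but with a different core, gives 120 nM in this assay, so a move towards a lower number is expected, with wide uncertainty.

The expected step is an at least 10-fold lower number from compound 3 to compound 4 (1.00 log units; beyond the scatter).

For compound 4 the estimated value is 5000 nM, with an expected range of 500 nM to 40000 nM.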

Compound 4, half-maximal inhibitory concentration: 14800 nM
Compound 4: the middle estimate sits 3.0-fold (0.47 log units) below what was measured; measured number inside the range.
By their numbers in this assay, from the lowest: compound 1; then compounds 4 and 2 (each within the scatter of the next). At a limit, above all of these: compound 3.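

Fluoro in place of trifluoromethyl gives the E-configured methoxy compounds their first number in this assay: an at least 3.3-fold lower number from compound 3 to compound 4 (0.52 log units; beyond the scatter). Compound 3 stands only at a limit, > 50000 nM, so the full size of this step cannot be read. With fluoro held, methoxy in place of hydrogen on an aromatic carbon gives a 120-fold higher number from compound 1 to compound 4 (2.09 log units; beyond the scatter), and the exchange does not bring the methoxy compound to the level of compound 1.

Still open, going by these compounds, is how an amine or a nitrile at this position would read on the shared core. Also open, on these data alone, is how trifluoromethyl would read on the core of compound 1.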